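The source may hold more compounds than are shown below. What is called first, only, known or untested is meant among the compounds shown, and "the series" means these compounds.

For the measured compounds named here, compound 2 `C[C@H](NC(=O)CN(c1nc(Cl)nc2[nH]cnc12)C1CC1)C(=O)O` stands highest of the two numbers so far in a functional assay on the whole organism (Tail, strain ICR) with Mus musculus as the target, in the tail flick test, with a stated time of 30 min, at a dose of 25 umol/kg by the oral route (on this read-out higher numbers stand for a stronger effect at the one dose given and lower numbers for a weaker effect), giving 48.1%; compound 1 `C[C@@H](O)[C@H](NC(=O)CN(c1nc(Cl)nc2[nH]cnc12)C1CC1)C(=O)O` gives 18.6%. Going by the values given here, the only measured step, a number 29.5 percentage points higher from compound 1 to compound 2 (beyond the scatter), went with methyl in place of 1-hydroxyethyl on a saturated chain carbon bound to an amide-type nitrogen and a carbonyl carbon. Compound 3 `O=C(O)CC[C@H](NC(=O)CN(c1nc(Cl)nc2[nH]cnc12)C1CC1)C(=O)O` differs from compound 2 by carboxymethyl in place of hydrogen on a saturated chain carbon, two bonds along the chain from an amide-type nitrogen and a carbonyl carbon. That earlier rise followed a smaller group near the same chain end, so adding a carboxymethyl is expected to pull this assay back down by a modest step. Compound 3 is expected to give 25%, between 5% and 45%, a step of a number 23.1 percentage points lower from compound 2 to compound 3 (beyond the scatter).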

Compound 3, a percentage reported as activity, at one dose (the size of the read-out at that dose, not a potency): 26.8%
For compound 3 the middle estimate is 1.8 percentage points below the measured one; low and high end bracket the measured number.
By their numbers in this assay, from the lowest: compounds 1 and 3 (each within the scatter of the next); then compound 2.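

In this assay, carboxymethyl in place of hydrogen on this chain carbon gives a number 21.3 percentage points lower from compound 2 to compound 3 (beyond the scatter) and so takes back much of what the methyl group had gained, which shows that a longer side chain ending in a carboxylic acid does not keep the effect. The two larger groups do not separate, with a number 8.2 percentage points higher from compound 1 to compound 3 (within the scatter) between 1-hydroxyethyl and 2-carboxyethyl. Nothing available explains either step. Still open, as far as these compounds go, is how a plain ethyl group, a hydroxymethyl group or a chain ending in an amine would fare at this carbon.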